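The source may report more compounds than this note shows. Statements on the series, on what has been measured and on what is new or still open speak of the compounds shown alone.

Within the data shown here, in a toxicity assay on MT4 cells (Homo sapiens) for cytotoxicity, read by MTT assay (a higher number here means that more compound is tolerated, a lower number that less compound is tolerated), compound 2 (`Cc1cc(-c2ccc(C#N)c(F)c2)cc(C)c1Oc1cc(N)nc(Nc2ccc(C#N)cc2)n1`) gives 5000 nM, the lower of the two numbers so far, with compound 1 (`Cc1cc(-c2ccc(Cl)cc2)cc(C)c1Oc1cc(N)nc(Nc2ccc(C#N)cc2)n1`) at 21500 nM. Compound 3 (`Cc1cc(-c2ccc(C#N)c(F)c2)ccc1Oc1cc(N)nc(Nc2ccc(C#N)cc2)n1`) has hydrogen in place of methyl on an aromatic carbon. Among the measured compounds shown here, the only measured step, a 4.3-fold lower number from compound 1 to compound 2 (0.63 log units; beyond the scatter), lies at a different place, so it offers a rough scale but no direction for this change. In this assay, no step beyond the scatter is expected, with a slightly higher number the tentative direction. The expected step is a 1.2-fold higher number from compound 2 to compound 3 (0.08 log units; within the scatter). For compound 3 the estimated value is 6000 nM, with an expected range of 2500 nM to 15000 nM.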

Compound 3, half-maximal cytotoxic concentration: 6600 nM
Beside the measured number, compound 3's estimate is 1.1-fold (0.04 log units) below it; measured number inside the range.
By their numbers in this assay, from the lowest: compounds 2 and 3 (each within the scatter of the next); then compound 1.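

In this assay hydrogen in place of methyl on an aromatic carbon, ortho to a large group, gives a 1.3-fold higher number from compound 2 to compound 3 (0.12 log units; within the scatter) and thus no step beyond the scatter. Among these compounds, this is the first reading at this position, and in the setting of compound 2 the methyl can be lost without a clear change in this number. From the compounds shown here alone, whether ethyl, methoxy or an amine at this carbon would stay within the scatter remains open. So does whether the same replacement behaves alike with the 4-chlorophenyl of compound 1. No measurement available here bears on the reason for this result.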